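Chain extension on the formyl-bearing ether of the series

A few compounds are considered here, and "the series" means these few. Any claim that something is new, unique, unknown or untested is made for them only; others in the source may bear on it.

Compound 3 `C#CCN(C)CCCCCOc1ccc(C=O)c(OC)c1` gives 5740 nM in an assay on BTI cells for inhibition of Amine oxidase [flavin-containing] B (Homo sapiens), read by fluorescence and Amplex Red, with a stated time of 15 min (a lower number here means a stronger inhibitor, a higher number a weaker inhibitor), the highest number among the three measured compounds. Compound 2 `C#CCN(C)CCCCCOc1cccc(OC)c1` gives 101 nM, and compound 1 `C#CCN(C)CCCCCOc1ccc2c(c1)OCCC2=O` gives 4 nM. Going by the values given here, the only single-point step that reaches compound 3 is a 57-fold higher number from compound 2 to compound 3 (1.75 log units; beyond the scatter); no other measured pair differs in one place.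

Compound 4 `C#CCN(C)CCCCCCOc1ccc(C=O)c(OC)c1` differs from compound 3 by (methyl(propargyl)amino)methyl in place of methyl(propargyl)amino on a saturated chain carbon, five bonds along the chain from an oxygen on an aromatic ring. Among the compounds with values here, no measured step changes the length of this chain. Within the data shown here, the one step in hand concerns the formyl group and says nothing about one more chain carbon between the amine and the ether oxygen. Among the measured compounds shown here, with no bearing step to lean on, the expected step of a 1.1-fold lower number from compound 3 to compound 4 (0.06 log units; within the scatter) in this assay is none beyond the scatter, direction open. Compound 4 is therefore estimated at 5000 nM in this assay. The expected range for compound 4 is estimated to run from 1500 nM to 16000 nM. This range is kept wide because the number for compound 3, 5740 nM, sits far from the other two measured compounds and nothing measured shows how that number answers to a longer chain.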

Compound 4, half-maximal inhibitory concentration: 552 nM
The estimate for compound 4 lay 9.1-fold (0.96 log units) above the measured number; measured number outside the range, below it.
By their numbers in this assay, from the lowest: compound 1; then compound 2; then compound 4; then compound 3.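

In this assay, the chain is a sensitive position in its own right: (methyl(propargyl)amino)methyl in place of methyl(propargyl)amino on a saturated chain carbon, five bonds along the chain from an oxygen on an aromatic ring, gives a 10-fold lower number from compound 3 to compound 4 (1.02 log units; beyond the scatter). Going by these compounds alone, the earlier compounds offered only one single-place step, the change at the aromatic carbon, a 57-fold higher number from compound 2 to compound 3 (1.75 log units; beyond the scatter), so the weak number of compound 3 could be read only against the formyl group; the new step shows that, with the formyl group kept, a change in the chain alone moves the number by a large amount and in the opposite direction. No measurement at hand bears on the reason for this step.

Still open, going by these compounds, is whether the same chain change gives a step of similar size and direction on compound 1 or compound 2, which carry no formyl group, or whether it depends on the formyl group. Also open, on these data alone, is how the number answers to a longer chain, such as 2-(methyl(propargyl)amino)ethyl at this place, or to a nitrile or a carboxylic acid in place of the formyl group on the chain of compound 4.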